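Working notes: carboxyfuran in place of thiophene

The source may hold more compounds than are shown below. What is called first, only, known or untested is meant among the compounds shown, and "the series" means these compounds.

Compound 3 `Cn1nc2c(=O)n(CC3(O)CCN(Cc4ccc(-c5cccs5)cc4Cl)CC3)cnc2c1-c1ccc(CN)cc1` gives 38.6 nM in an assay on isolated protein for inhibition of ubiquitin carboxyl-terminal hydrolase 7 (Homo sapiens), with stated times of 30 min and 2 h (a higher number here means a weaker inhibitor, a lower number a stronger inhibitor), the lowest of the three numbers obtained so far. Compound 1 `Cn1cc(-c2ccc(CN3CCC(O)(Cn4cnc5c(-c6ccc(CN)cc6)n(C)nc5c4=O)CC3)c(Cl)c2)cn1` gives 291 nM and compound 2 `Cn1nc2c(=O)n(CC3(O)CCN(Cc4ccc(-c5ncco5)cc4Cl)CC3)cnc2c1-c1ccc(CN)cc1` gives 1120 nM. The steps to compound 3 were a 7.5-fold lower number from compound 1 to compound 3 (0.88 log units; beyond the scatter) and a 29-fold lower number from compound 2 to compound 3 (1.46 log units; beyond the scatter); the step of a 3.8-fold higher number from compound 1 to compound 2 (0.59 log units; beyond the scatter) separates the other two. Compound 4 `Cn1nc2c(=O)n(CC3(O)CCN(Cc4ccc(-c5ccc(C(=O)O)o5)cc4Cl)CC3)cnc2c1-c1ccc(CN)cc1` differs from compound 3 by 5-carboxyfuran-2-yl in place of thiophen-2-yl on an aromatic carbon. Within the data shown here, no measured step swaps thiophen-2-yl for a furan or introduces a carboxylic acid, so the bearing steps are only the three above, which show that the aromatic group at this position moves the number by modest to large amounts in either direction. Compound 4 is therefore expected to give 350 nM (range 90 nM to 1400 nM), the step of a 9.1-fold higher number from compound 3 to compound 4 (0.96 log units; beyond the scatter) being estimated as a return toward the weaker members.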

Compound 4, half-maximal inhibitory concentration: 753 nM
Compound 4: middle estimate off by 2.2-fold (0.33 log units), on the low side; the range from low to high includes it.
By their numbers in this assay, from the lowest: compound 3; then compound 1; then compounds 4 and 2 (each within the scatter of the next).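

The change shows a 20-fold higher number from compound 3 to compound 4 (1.29 log units; beyond the scatter) and leaves thiophen-2-yl alone with the lowest number of the four groups at this position. Against the other groups, a 1.5-fold lower number from compound 2 to compound 4 (0.17 log units; within the scatter) leaves 5-carboxyfuran-2-yl indistinguishable from 1,3-oxazol-2-yl, while a 2.6-fold higher number from compound 1 to compound 4 (0.41 log units; beyond the scatter) puts it on the weaker side of 1-methyl-1H-pyrazol-4-yl. No available evidence accounts for these differences.

The compounds shown leave open whether the furan ring or the carboxylic acid carries the step from thiophen-2-yl. An unsubstituted furan-2-yl, or a thiophen-2-yl bearing the carboxylic acid, would separate the two.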